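The compounds below may be only part of what the source reports. "The series", "measured", "known", "first", "only" and "open" are said of these compounds alone.

Compound 1 `O=c1cc(-c2ccccc2)oc2cccc(OCCCN3CCC(O)CC3)c12` in an assay on isolated protein (Cavia porcellus) with Sigma non-opioid intracellular receptor 1 (Homo sapiens) as the target, read by radioligand binding (a lower number here means a stronger inhibitor, a higher number a weaker inhibitor), gives 91 nM. Compound 2 `O=c1cc(-c2ccccc2)oc2cccc(OCCCCCCCN3CCC(O)CC3)c12` gives 65 nM. Compound 3 `CN(C)CCCCCCOc1ccc2oc(-c3ccccc3)cc(=O)c2c1` gives 335 nM.

Compound 3 has the highest of the three numbers; its gap to compound 1 and its gap to compound 2 each lie beyond the scatter, so compound 3 is the weakest inhibitor among the three. Compound 4 `CN(C)CCCCCCCCCOc1ccc2oc(-c3ccccc3)cc(=O)c2c1` has not yet been measured. It differs from compound 3 in one place: 3-(dimethylamino)propyl in place of dimethylamino on a saturated chain carbon, six bonds along the chain from an oxygen on an aromatic ring. Going by the values given here, no step between two measured compounds with this kind of change is known. Compound 1 and compound 2 also differ in chain length, and their numbers sit within the scatter of each other. The step of a 1.3-fold lower number from compound 3 to compound 4 (0.13 log units; within the scatter) is therefore expected to be small, probably toward a slightly lower number but not clearly beyond the scatter. Compound 4 is expected at 250 nM, within a range from 100 nM to 650 nM.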

Compound 4, half-maximal inhibitory concentration: 202 nM
Compound 4: middle estimate off by 1.2-fold (0.09 log units), on the high side; measured number inside the range.
By their numbers in this assay, from the lowest: compounds 2 and 1 (each within the scatter of the next); then compounds 4 and 3 (each within the scatter of the next).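

In this assay, putting 3-(dimethylamino)propyl in place of dimethylamino on a saturated chain carbon, six bonds along the chain from an oxygen on an aromatic ring, gives a 1.7-fold lower number from compound 3 to compound 4 (0.22 log units; within the scatter). Going by these compounds alone, this is the first measured step for this change at this position, and it shows that this longer chain leaves the number within the usual scatter. No measured evidence bears on this result. From the compounds shown here alone, whether a still longer chain, or a diethylamino or morpholine group in place of dimethylamino, would do the same remains open.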